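The compounds below may be only part of what the source reports. "The series", "measured", "known", "first", "only" and "open" are said of these compounds alone.

The measured compounds and their solubility values:

Compound 1, `COc1ccc(F)cc1CNCCCNc1ccnc2cc(Cc3ccc(C#N)cc3)ccc12`: in a physicochemical assay for solubility, with a stated time of 18 h, at pH 7.4 (on this read-out lower numbers stand for lower solubility and higher numbers for higher solubility), compound 1 gives 4200 nM
Compound 2, `Clc1ccc(Oc2ccc3c(NCCCNCc4ccco4)ccnc3c2)cc1`: compound 2 gives 14500 nM
Compound 3, `COc1cccc(CNCCCNc2ccnc3cc(Cc4ccc(C#N)cc4)ccc23)c1O`: compound 3 gives 4200 nM

Compound 1 stands level with compound 3, and the two together are the lowest of the three numbers; compound 2 lies higher than both, and its gap to compound 1 is beyond the usual scatter. Compound 2 differs from compound 1 in more than one place, so its number only shows where a different pairing of groups landed.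

Among the compounds with values here, the only single-point step measured, no change at the digits printed from compound 1 to compound 3 (within the scatter), exchanges the group on a saturated chain carbon bound to an amine nitrogen. The step to compound 4, `COc1ccc(F)cc1CNCCCNc1ccnc2cc(-c3ccc(C(C)(C)C)cc3)ccc12`, changes a different part of the molecule: 4-(tert-butyl)phenyl in place of 4-cyanobenzyl on an aromatic carbon. Within the data shown here, no measured step touches this aromatic carbon, so nothing in the data sets the size or direction of the coming step; the expectation below rests on the structural change alone and is loosely held.

Compound 4 is expected to give 1500 nM in this assay, within a range of 400 nM to 6000 nM. This expected figure corresponds to the step of a 2.8-fold lower number from compound 1 to compound 4 (0.45 log units; beyond the scatter).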

Compound 4, solubility: 32000 nM
Beside the measured number, compound 4's estimate is 21-fold (1.33 log units) below it; the measured number lies above the stated range.
By their numbers in this assay, from the lowest: compounds 1 and 3 (each within the scatter of the next); then compound 2; then compound 4.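

Within the data shown here, exchanging 4-cyanobenzyl for 4-(tert-butyl)phenyl on this aromatic carbon gives a 7.6-fold higher number from compound 1 to compound 4 (0.88 log units; beyond the scatter) in this assay, so this is the first place where a single change moves the read-out beyond the scatter, unlike the chain-carbon exchange, which gave no change at the digits printed from compound 1 to compound 3 (within the scatter). The higher number arrives with a group that has no hydrogen-bond acceptor in place of one that has one, and the step alters two things together: the nitrile gives way to tert-butyl, and the benzyl unit gives way to a phenyl bound directly to the aromatic carbon. No measurement is available here that explains this rise.

The compounds shown leave open which of those two alterations carries the step, a question that 4-cyanophenyl or 4-(tert-butyl)benzyl on the same aromatic carbon would help to settle. They also leave open how a simple phenyl, or a phenyl bearing a carboxylic acid or an amine, would read at this place, and whether the step would hold with 2-hydroxy-3-methoxyphenyl on the chain.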